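Swapping the Aryl Group on the Piperazine Amide

This account rests on a few compounds, and the source may have more. Where it says the series, first, only, none or still open, it means among the compounds named here.

Compound 1 `CC1(c2ccccc2)CC(=O)N(CC(=O)N2CCN(c3ccccc3)CC2)C1=O` and compound 2 `CC1(c2ccccc2)CC(=O)N(CC(=O)N2CCN(c3ccc(Cl)cc3)CC2)C1=O` share a core that carries a piperazine amide bearing an aromatic group. In a functional assay on the whole organism (strain CD-1) with Mus musculus as the target, with a stated time of 2 h (on this read-out higher numbers stand for an effect only at larger amounts of compound and lower numbers for an effect already at smaller amounts), compound 1 gives 300 mg/kg, and in this assay compound 2 gives 300 mg/kg. For the measured compounds named here, the only measured step between them, no change at the digits printed from compound 1 to compound 2 (within the scatter), shows that adding a chlorine to the aromatic ring left the read-out where it was. Compound 2 therefore stands level with compound 1 on the numbers shown.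

Compound 3 `CC1(c2ccccc2)CC(=O)N(CC(=O)N2CCN(c3ncccn3)CC2)C1=O` differs from compound 2 in that (pyrimidin-2-yl in place of 4-chlorophenyl on an amine nitrogen in a ring). Going by the values given here, the one measured step bears on this change only loosely: it tells that a substituent on the aromatic ring made no difference in this assay, but it says nothing about exchanging the ring itself for a ring with two hetero atoms. Among the compounds with values here, with no step pointing in either direction, compound 3 is expected to behave like compound 2, and the step of no change at the digits printed from compound 2 to compound 3 (within the scatter) is estimated to stay within the scatter. Compound 3 is estimated to reach 300 mg/kg in this assay, with a plausible range from 100 mg/kg to 1000 mg/kg.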

Compound 3, minimum effective dose: 100 mg/kg
For compound 3 the middle estimate is 3.0-fold (0.48 log units) above the measured one; measured number inside the range.
By their numbers in this assay, from the lowest: compound 3; then compounds 1 and 2 (each within the scatter of the next).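

Exchanging the aromatic ring itself moved the read-out in this assay where adding a chlorine had not: 4-chlorophenyl replaced by pyrimidin-2-yl gives a 3.0-fold lower number from compound 2 to compound 3 (0.48 log units; beyond the scatter), and phenyl replaced by pyrimidin-2-yl gives a 3.0-fold lower number from compound 1 to compound 3 (0.48 log units; beyond the scatter). Both steps are modest but lie beyond the scatter, so compound 3 shows an effect at a smaller amount than either of the compounds with a carbon-only ring, and this position on the amine nitrogen in the ring responds to the kind of ring it carries, which the chloro step alone could not show. Nothing available here accounts for the difference between the ring with two hetero atoms and the carbon-only rings.

The compounds shown leave open whether a pyridin-2-yl group, with a single ring nitrogen, would read like compound 3 or like compounds 1 and 2. They also leave open what a group with no aromatic ring, such as cyclohexyl or methyl, would give on the same nitrogen, and whether a chloro group on the pyrimidin-2-yl ring would leave the number unchanged as it did on phenyl.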